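The source may report more compounds than this note shows. Statements on the series, on what has been measured and on what is new or still open speak of the compounds shown alone.

The measured compounds:
- compound 1 `CC(C)n1cnc2c(Nc3ccccc3)nc(NCOCc3ccc(C(=O)Nc4ccccc4N)cc3)nc21` gives 50.2% in a functional assay on HepG2 cells (Homo sapiens) for antiproliferative activity, read by CCK-8 assay, with a stated time of 72 h, tested at 8 uM; a lower number here means a weaker effect, a higher number a stronger effect of the compound at the concentration tested
- compound 2 `CC(C)n1cnc2c(Nc3ccccc3)nc(NCOCc3ccc(/C=C/C(=O)Nc4ccccc4N)cc3)nc21` gives 40.8% in this assay
- compound 3 `CC(C)n1cnc2c(Nc3cccc(Cl)c3)nc(NCOCc3ccc(C(=O)Nc4ccccc4N)cc3)nc21` gives 60.5% in this assay

Among these three numbers compound 1 stands second highest. Its nearest neighbour is compound 2, reached by a number 9.4 percentage points lower from compound 1 to compound 2 (within the scatter), which is within the scatter. The further one is compound 3, reached by a number 10.3 percentage points higher from compound 1 to compound 3 (beyond the scatter), a modest step beyond the scatter.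

Compound 4 `Nc1ccccc1NC(=O)c1ccc(COCNc2nc(Nc3ccccc3)c3ncn(C4CCCC4)c3n2)cc1` differs from compound 1 in one place: cyclopentyl in place of isopropyl on an aromatic nitrogen. Neither measured step bears directly on this change. The step from compound 1 to compound 2 alters the carbonyl-bearing group on the benzene ring, and the step from compound 1 to compound 3 alters the aniline ring; both leave the group on the aromatic nitrogen untouched. Among the compounds with values here, the only guidance is that both measured steps on this core are small, one within the scatter and one modest. The step of a number 3.8 percentage points higher from compound 1 to compound 4 (within the scatter) is therefore expected to be none beyond the scatter. Compound 4 is estimated at 54%, within a range from 40% to 68%.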

Compound 4, a percentage reported as inhibition, at one concentration (the size of the read-out at that concentration, not a potency): 66.9%
For compound 4 the middle estimate is 12.9 percentage points below the measured one, and the stated range covers the measured number.
By their numbers in this assay, from the lowest: compounds 2 and 1 (each within the scatter of the next); then compounds 3 and 4 (each within the scatter of the next).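

In this assay, within the data shown here, putting cyclopentyl in place of isopropyl on the aromatic nitrogen gives a number 16.7 percentage points higher from compound 1 to compound 4 (beyond the scatter), the first sign that the group at this position affects the read-out, since both earlier steps left it untouched. Both groups consist of carbon only and carry no hydrogen-bond donors or acceptors, so this step reflects a change in the carbon group alone, from an open group of 3 heavy atoms to a five-membered ring of 5. Nothing measured here explains why the number moves with this change.

The compounds shown leave open how a methyl, a cyclohexyl or a piperidine ring on this nitrogen would read out. They also leave open whether the cyclopentyl step would hold alongside the chloro group on the aniline ring.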